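The compounds below may be only part of what the source reports. "The series", "measured", "known", "first", "only" and "open" are said of these compounds alone.

Working notes on the series. Compound 1 `COc1ccc(-c2cc(/C=C/C(=O)c3ccc(N)cc3)[nH]n2)cc1` and compound 2 `COc1ccc(-c2cc(/C=C/C(=O)c3ccc(N)cc3)[nH]n2)cc1OC` share one core, which differs from that of compound 3 `COc1cc(C(=O)/C=C/c2cc(-c3cc(OC)c(OC)c(OC)c3)n[nH]2)cc(OC)c1OC` in a way that is not broken down here. In a functional assay on SF-539 cells (Homo sapiens) for inhibition, read by sulforhodamine B assay, with a stated time of 48 h (on this read-out higher numbers stand for weaker inhibition of growth and lower numbers for stronger inhibition of growth), compound 1 gives 3480 nM, compound 2 gives 3530 nM and compound 3 gives 2830 nM; all three values lie within the scatter of one another. The change hydrogen in place of methoxy on an aromatic carbon made the step of a 1.0-fold lower number from compound 2 to compound 1 (0.01 log units; within the scatter). Compound 4 `COc1ccc(-c2cc(/C=C/C(=O)c3cc(OC)c(OC)c(OC)c3)[nH]n2)cc1OC` is not yet measured; it arises from compound 3 by hydrogen in place of methoxy on an aromatic carbon, the same kind of change, though here the place is also meta to a methoxy group (2 heavy atoms). The step from compound 3 to compound 4 in this assay is expected to be a 1.0-fold higher number from compound 3 to compound 4 (0.01 log units; within the scatter), resting on the flat step a 1.0-fold lower number from compound 2 to compound 1 (0.01 log units; within the scatter). Compound 4 is thus estimated at 2900 nM, between 1500 nM and 6000 nM.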

Compound 4, concentration for total growth inhibition: 1480 nM
Beside the measured number, compound 4's estimate is 2.0-fold (0.29 log units) above it; measured number below the stated range.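

In this assay, hydrogen in place of methoxy on an aromatic carbon gives a 1.9-fold lower number from compound 3 to compound 4 (0.28 log units; within the scatter). Set beside the earlier step, the change carries from one core to the other with no difference that can be told apart: the same change on two cores in this assay, a 1.0-fold lower number (0.01 log units; within the scatter) from compound 2 to compound 1 and a 1.9-fold lower number (0.28 log units; within the scatter) from compound 3 to compound 4, 1.9-fold (0.28 log units) apart, within the scatter of two such steps. This gives no sign that the core alters the step, but two pairs, each with a step inside the scatter, do not show that the change is without effect or that the two cores respond alike.

As far as these compounds go, whether a hydroxyl or a longer chain such as ethoxy in place of methoxy would give a step beyond the scatter remains open. So does whether the step would hold on a third core.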